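The compounds below may be only part of what the source reports. "The series", "measured", "known", "first", "only" and "open" are said of these compounds alone.

In an assay on THP-1 cells for antagonist activity at Toll-like receptor 8 (Homo sapiens) (on this read-out lower numbers stand for stronger inhibition and higher numbers for weaker inhibition), compound 1, `Cc1cc(-c2ccnc3[nH]ncc23)cnc1OCC12CCC(N)(CC1)CC2`, reaches the limit of the assay, < 1 nM, and so gives no number of its own. Compound 3, `Cn1ncc2c(-c3ccc(OCC45CCC(N)(CC4)CC5)c(F)c3)nc(N)nc21`, gives 18 nM in this assay. Compound 2, `Cn1nc(-c2ccc(OCC34CCC(O)(CC3)CC4)c(F)c2)c2cnc(N)nc21`, gives 75 nM in this assay, the higher of the two full numbers. The gap between compound 2 and compound 3 is beyond the usual scatter of repeated measurements. Compound 4, `Cn1nc(-c2ccc(OCC3CCNCC3)c(F)c2)c2cnc(N)nc21`, has not yet been measured in this assay. It differs from compound 2 in a single place: a group of 6 heavy atoms (5 carbon, 1 nitrogen; one six-membered non-aromatic ring with 1 hetero atom) in place of a group of 9 heavy atoms (8 carbon, 1 oxygen; 2 six-membered non-aromatic rings of carbon only), on a saturated chain carbon bound to an oxygen on an aromatic ring. For the measured compounds named here, no pair of measured compounds shows this same change, so there is no measured step to lean on, and the expectation rests on the spread of the values already in hand. A modest move toward a lower number is expected, not clearly beyond the scatter. Compound 4 is expected to give 40 nM in this assay, with a likely range from 10 nM to 150 nM. The step expected is a 1.9-fold lower number from compound 2 to compound 4 (0.27 log units; within the scatter).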

Compound 4, half-maximal inhibitory concentration: 60 nM
The estimate for compound 4 lay 1.5-fold (0.18 log units) below the measured number, within the range that was stated.
By their numbers in this assay, from the lowest: compound 3; then compounds 4 and 2 (each within the scatter of the next). At a limit, below all of these: compound 1.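

In this assay, this position now has its first measured step: a 1.3-fold lower number from compound 2 to compound 4 (0.10 log units; within the scatter). Replacing the group of 9 heavy atoms, with its two carbon-only rings and its oxygen, by the smaller piperidin-4-yl ring therefore produces no change that can be told from the scatter, so on this core the position accepts both groups. No measurement shown bears on why these two different groups give such close numbers.

On these data alone, it remains open whether the same holds for other groups at this position, such as a piperidine with a methyl group on its nitrogen or a plain cyclohexyl ring. Also open, as far as these compounds go, is how an amine in place of the oxygen of the larger group would read on this same core, since compound 3 differs from compound 2 in more than one place.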